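The source may report more compounds than this note shows. Statements on the series, on what has been measured and on what is new or still open speak of the compounds shown alone.

Compound 1 `COc1ccc(F)cc1CNCCCNc1ccnc2cc(Cc3cc(C)cc(C)c3)ccc12`: 4200 nM
Compound 2 `COc1ccc(F)cc1CNCCCNc1ccnc2cc(CCc3ccccc3)ccc12`: 4200 nM
Compound 3 `CCC(CC)c1ccc2c(NCCCNCc3cc(F)ccc3OC)ccnc2c1`: 4200 nM

In a physicochemical assay for solubility, with a stated time of 18 h, at pH 7.4 (on this read-out lower numbers stand for lower solubility and higher numbers for higher solubility), compound 3 gives 4200 nM, level with compound 1 and compound 2 on the digits shown. The three measured steps all rest on the same shared core and differ only in the group carried on one aromatic carbon: no change at the digits printed from compound 1 to compound 2 (within the scatter); no change at the digits printed from compound 1 to compound 3 (within the scatter); no change at the digits printed from compound 2 to compound 3 (within the scatter). Compound 4 `COc1ccc(F)cc1CNCCCNc1ccnc2cc(Cc3cccc(C(F)(F)F)c3)ccc12` alters that same position: 3-(trifluoromethyl)benzyl in place of pentan-3-yl on an aromatic carbon. The measured steps that bear on it cover a swap between aryl-bearing groups and a swap between pentan-3-yl and an aryl-bearing group, each with no change within the scatter. A step of the same kind is therefore expected for compound 4, no change at the digits printed from compound 3 to compound 4 (within the scatter), none beyond the scatter. Compound 4 is estimated at 4200 nM, within 2000 nM to 8500 nM.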

Compound 4, solubility: 4200 nM
The estimate for compound 4 equals the measured number at the digits printed; the measured number falls inside the stated range.
By their numbers in this assay, from the lowest: compounds 1, 2, 3 and 4 (each within the scatter of the next).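

Within the data shown here, measured in this assay this position shows no change at the digits printed from compound 3 to compound 4 (within the scatter) and no change at the digits printed from compound 2 to compound 4 (within the scatter) and also no change at the digits printed from compound 1 to compound 4 (within the scatter) even though 3-(trifluoromethyl)benzyl is the first group here to carry fluorine at this position. Among these four compounds, then, a group with trifluoromethyl on its aromatic ring reads the same as the ringless pentan-3-yl and the two fluorine-free aryl-bearing groups. No measurement offered here explains this flat result. As far as these compounds go, whether an amine or a carboxylic acid on this aromatic carbon would shift the read-out remains open.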